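This account rests on a few compounds, and the source may have more. Where it says the series, first, only, none or still open, it means among the compounds named here.

Three compounds of this series have numbers in a functional assay on MCF7 cells (Homo sapiens) for cytotoxicity, read by MTT assay, with a stated time of 48 h; a lower number here means a stronger inhibitor, a higher number a weaker inhibitor. Compound 1 `COc1ccc(CNC(=O)CSc2nc3ccc(NC(=O)c4ccc(Cl)cc4)cc3s2)cc1` gives 19200 nM; compound 2 `CC(=O)Nc1ccc2nc(SCC(=O)NCc3ccccc3)sc2c1` gives 17600 nM; compound 3 `COc1ccc(CNC(=O)CSc2nc3ccc(NC(C)=O)cc3s2)cc1` gives 20500 nM. Compound 3 holds the highest of the three numbers, but the gaps are small: a 1.1-fold higher number from compound 1 to compound 3 (0.03 log units; within the scatter) and a 1.2-fold higher number from compound 2 to compound 3 (0.07 log units; within the scatter) both sit inside the scatter, so no order among the three is established.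

Compound 4 `COc1ccc(CNC(=O)CSc2nc3ccc(NC(=O)c4ccccc4)cc3s2)cc1` differs from compound 3 by phenyl in place of methyl on a carbonyl carbon, that is, acetamido to benzamido. Among the measured compounds shown here, the step that bears on it is the one from compound 1, where a larger group on the same carbonyl carbon changed little: a 1.1-fold higher number from compound 1 to compound 3 (0.03 log units; within the scatter). A step of that kind is therefore expected for compound 4 in this assay, a 1.1-fold lower number from compound 3 to compound 4 (0.03 log units; within the scatter), not beyond the scatter in either direction. The estimate for compound 4 is 19000 nM, with a range from 9000 nM to 40000 nM.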

Compound 4, half-maximal inhibitory concentration: 21200 nM
Beside the measured number, compound 4's estimate is 1.1-fold (0.05 log units) below it, and the stated range covers the measured number.
By their numbers in this assay, from the lowest: compounds 2, 1, 3 and 4 (each within the scatter of the next).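

Both changes around this amide leave the number in this assay unmoved: phenyl in place of methyl on the carbonyl carbon (a 1.0-fold higher number from compound 3 to compound 4 (0.01 log units; within the scatter)) and hydrogen in place of chloro on an aromatic carbon (a 1.1-fold higher number from compound 1 to compound 4 (0.04 log units; within the scatter)). The acetamido, benzamido and chlorinated benzamido forms therefore cannot be told apart in this assay. Nothing measured here accounts for this flat reading.

Open, from the compounds shown here alone, is whether an amine or a carboxylic acid on the benzoyl ring, or a longer chain in place of methyl, would give a step beyond the scatter. Going by these compounds, the effect of changes to the shared core also remains open.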